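A few compounds are considered here, and "the series" means these few. Any claim that something is new, unique, unknown or untested is made for them only; others in the source may bear on it.

In a functional assay on HT-29 cells (Homo sapiens) for antiproliferative activity, read by MTT assay, with a stated time of 24 h (a higher number here means a weaker inhibitor, a lower number a stronger inhibitor), the three measured compounds stand as follows.
Compound 1, `COc1ccc(C(=O)/C=C/c2cc(OC)c(OC)c(OC)c2)c2c1C=CC(C)(C)O2`, gives a limit of > 10000 nM.
Compound 2, `COc1ccc(C(=O)/C=C/c2ccc(N(C)C)cc2)c2c1C=CC(C)(C)O2`, gives 1870 nM.
Compound 3, `COc1ccc(C(=O)/C=C/c2cccc3ccccc23)c2c1C=CC(C)(C)O2`, gives a limit of > 10000 nM.

For the measured compounds named here, compound 2 thus holds the only actual number in this set; the other two values are limits (the limit of > 10000 nM in this assay, at which 2 of the 3 values shown sit), so no measured step between two numbers exists, and the size of any change can only be guessed. Compound 4, `COc1ccc(C(=O)/C=C/c2ccc(Cl)cc2)c2c1C=CC(C)(C)O2`, is not yet measured. Its change from compound 2 is chloro in place of dimethylamino on an aromatic carbon. In this assay the step from compound 2 to compound 4 is expected to weaken inhibition by a 3.2-fold higher number from compound 2 to compound 4 (0.51 log units; beyond the scatter). Compound 4 is therefore estimated at 6000 nM, with a range of 2000 nM to 20000 nM.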

Compound 4, half-maximal inhibitory concentration: > 10000 nM
Compound 4 was reported as a limit (the forecaster's own chance of this, stated with the estimate: 45%); at least 1.6-fold (0.22 log units) between middle value and limit.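

Chloro in place of dimethylamino, on this aromatic carbon para to a large group, gives the first step that can be read in this assay (an at least 5.3-fold higher number from compound 2 to compound 4 (0.72 log units; beyond the scatter)). For the compounds shown here, with this one change, the only measured number in the set is lost, and the step gives a lower bound on the size of the change, not its full size. The value of compound 4 is a limit and not a number, and it joins the others at that limit: the limit of > 10000 nM in this assay, at which 3 of the 4 values shown sit.

Going by these compounds, it remains open how far a simple amine, a methoxy group or a pyrrolidine at this position would hold the number of compound 2. On these data alone, it also remains open how much weaker compound 4 really is.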